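The source may hold more compounds than are shown below. What is called first, only, known or untested is meant among the compounds shown, and "the series" means these compounds.

Working notes on the series. Three members of the shared core have been measured in a functional assay on MCF7 cells (Homo sapiens) for inhibition, read by MTT assay, with a stated time of 72 h; on this read-out higher numbers stand for weaker inhibition and lower numbers for stronger inhibition. Compound 1 `CN(C(=O)NC(=O)c1ccc(Cl)cc1Cl)c1nc(C(F)(F)F)c(C(=O)N/N=C/c2cccc(C(F)(F)F)c2)s1` gives 10.7 ug/mL, compound 2 `CN(C(=O)NC(=O)c1cccc(C(F)(F)F)c1)c1nc(C(F)(F)F)c(C(=O)N/N=C/c2ccccc2C(F)(F)F)s1` gives 7.69 ug/mL, and compound 3 `CN(C(=O)NC(=O)c1ccc(F)c(F)c1)c1nc(C(F)(F)F)c(C(=O)N/N=C/c2ccccc2C(F)(F)F)s1` gives 8.21 ug/mL. Compound 3 holds the second highest of the three numbers; compound 2 sits nearest to it and compound 1 furthest, and both gaps lie within the scatter, so the three measured values are not distinguishable from each other in this assay.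

Going by the values given here, the one single-point step measured so far, a 1.1-fold higher number from compound 2 to compound 3 (0.03 log units; within the scatter), exchanges the aryl group on the carbonyl carbon and moves the number by an amount within the scatter.

Compound 4 `CN(C(=O)NC(=O)c1ccc(Cl)cc1Cl)c1nc(C(F)(F)F)c(C(=O)N/N=C/c2ccccc2C(F)(F)F)s1` is the next member: 2,4-dichlorophenyl in place of 3,4-difluorophenyl on a carbonyl carbon. Among the compounds with values here, this is again an aryl exchange on the carbonyl carbon, the same kind of change as the one measured step. Within the data shown here, compound 1 also carries the 2,4-dichlorophenyl group and its value sits within the scatter of compound 3, though compound 1 differs from compound 4 elsewhere and no single-point step joins them.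

Taken together, no step beyond the scatter is expected in this assay for compound 4; the estimated move is a 1.2-fold higher number from compound 3 to compound 4 (0.06 log units; within the scatter). Compound 4 is expected to give about 9.5 ug/mL, with a likely range from 5 ug/mL to 18 ug/mL.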

Compound 4, half-maximal inhibitory concentration: 9.12 ug/mL
Compound 4: middle estimate off by 1.0-fold (0.02 log units), on the high side; the range from low to high includes it.
By their numbers in this assay, from the lowest: compounds 2, 3, 4 and 1 (each within the scatter of the next).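

In this assay, three aryl groups on the carbonyl carbon can now be compared with the rest of the molecule held fixed: 2,4-dichlorophenyl in place of 3,4-difluorophenyl gives the step (a 1.1-fold higher number from compound 3 to compound 4 (0.05 log units; within the scatter)), and 2,4-dichlorophenyl in place of 3-(trifluoromethyl)phenyl gives the step (a 1.2-fold higher number from compound 2 to compound 4 (0.07 log units; within the scatter)), so this position has not yet separated these three groups. The series also gains its first measured step at a second place, the carbon with a double bond to nitrogen, where 2-(trifluoromethyl)phenyl in place of 3-(trifluoromethyl)phenyl gives the step (a 1.2-fold lower number from compound 1 to compound 4 (0.07 log units; within the scatter)), which likewise lies within the scatter and so shows no preference between these two aryl groups. Nothing available explains why these exchanges leave the number within the scatter.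

Every group compared at the carbonyl carbon is a phenyl ring bearing fluorine, chlorine or trifluoromethyl, so the compounds shown leave open whether an unsubstituted phenyl, a methoxyphenyl, an aliphatic amine or a longer alkyl chain there would move the number beyond the scatter. At the carbon with a double bond to nitrogen, only two placements of trifluoromethyl on phenyl can be compared, and a carboxylic acid or a hydroxyl group on that ring remains an open question.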